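A few compounds are considered here, and "the series" means these few. Any claim that something is new, unique, unknown or untested is made for them only; others in the source may bear on it.

Measured so far in a functional assay on MCF7 cells (Homo sapiens) for inhibition, read by sulforhodamine B assay, with a stated time of 48 h; on this read-out lower numbers stand for stronger inhibition of growth and higher numbers for weaker inhibition of growth:
Compound 1 `CCc1ccc(NC(=S)N/N=C/c2cccs2)cc1` gives > 100000 nM, which is a limit of the assay and not a number.
Compound 2 `S=C(N/N=C/c1cccs1)Nc1cccnc1` gives > 100000 nM, again a limit.
Compound 3 `C=CCNC(=S)N/N=C/c1cccs1` gives > 100000 nM, again a limit.

Compound 1 therefore stands where every measured compound stands: at the limit of > 100000 nM in this assay, at which 3 of the 3 values shown sit, so no number tells how strongly it inhibits growth. Compound 4 `S=C(N/N=C/c1cccs1)Nc1ccc(Br)cc1` differs from compound 1 in one place: bromo in place of ethyl on an aromatic carbon. Among the measured compounds shown here, no step between two measured compounds exists to guide the expectation, and all three measured values are limits. I expect the step that the limit leaves unreadable from compound 1 to compound 4 in this assay to be no larger than the scatter, in no clear direction. My estimate for compound 4 is 150000 nM, with a range from 40000 nM to 600000 nM, and a limit remains the most likely outcome.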

Compound 4, concentration for 50% growth inhibition: < 740 nM
Compound 4 ended at the assay's limit; the forecaster's own chance of this, stated with the estimate: 80%; middle value at least 200-fold (2.30 log units) from the limit.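

In this assay compound 4 gives < 740 nM, which is a limit of the assay and not a number. Even so, bromo in place of ethyl on this aromatic carbon gives an at least 130-fold lower number from compound 1 to compound 4 (2.13 log units; beyond the scatter), a large step. The earlier compounds shown here all sat at one limit and showed no growth inhibition that could be read, whereas this single change at this one place on the shared core brings it into view.

How strong compound 4 really is remains unreadable. The compounds shown also leave open whether other groups at this place, such as chloro, methoxy or an amine, would act like bromo or like ethyl.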